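Swapping a Chlorophenyl for a Naphthyl on an Inactive Core

The source may hold more compounds than are shown below. What is called first, only, known or untested is meant among the compounds shown, and "the series" means these compounds.

Measured so far in a functional assay on HCT-116 cells (Homo sapiens) for antiproliferative activity, read by MTT assay, with a stated time of 48 h; a lower number here means a stronger inhibitor, a higher number a weaker inhibitor:
- compound 1 `O=C(/C=C/c1ccc([N+](=O)[O-])cc1)Nc1cc(Sc2ncn[nH]2)c(O)c2ccccc12` reaches only the assay limit > 100000 nM.
- compound 2 `O=C(Nc1cc(Sc2ncn[nH]2)c(O)c2ccccc12)c1cccc(Cl)c1` also gives only the limit > 100000 nM.
- compound 3 `O=C(Nc1cc(Sc2ncnc3nc[nH]c23)c(O)c2ccccc12)c1ccc([N+](=O)[O-])cc1` likewise stops at the limit > 100000 nM.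

For the measured compounds named here, compound 2 therefore stands where every compound so far stands: at the limit, as the limit of > 100000 nM in this assay, at which 3 of the 3 values shown sit, records, with no number behind it. Compound 4 `O=C(Nc1cc(Sc2ncn[nH]2)c(O)c2ccccc12)c1ccc2ccccc2c1` differs from compound 2 in one place: naphthalen-2-yl in place of 3-chlorophenyl on a carbonyl carbon. Going by the values given here, no step between two measured compounds exists here, so there is nothing to compare this change against. Because every value sits at the limit of > 100000 nM in this assay, at which 3 of the 3 values shown sit, the step of a number no higher from compound 2 to compound 4 (the limit leaves the size open) is expected to be none beyond the scatter. Compound 4 is expected to give about 100000 nM, between 20000 nM and 300000 nM, most likely again reported as a limit.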

Compound 4, half-maximal inhibitory concentration: > 100000 nM
Compound 4: no number, only a limit (the forecaster's own chance of this, stated with the estimate: 75%); the middle value sits exactly at the limit.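

For the compounds shown here, compound 2 and compound 4 both stop at a limit in this assay, so no step between them can be read. Whether naphthalen-2-yl and 3-chlorophenyl differ in effect at all stays open, as does which change would bring any measurable number, with every compound resting at one point: the limit of > 100000 nM in this assay, at which 4 of the 4 values shown sit.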